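The compounds below may be only part of what the source reports. "The series", "measured", "known", "first", "only" and "open" are said of these compounds alone.

In an ADME assay on the whole organism for metabolic stability, with Rattus norvegicus as the target, at a dose of 10 mg/kg by the intraperitoneal route (a lower number here means that the compound disappears faster, a higher number that the compound lasts longer), compound 2 `Cc1c(OCCCCOc2ccc(F)c(C(=O)O)c2)ccc(C(=O)CC(C)(C)C)c1O` gives 1.33 h. Compound 3 `Cc1c(OCCCCOc2ccc(C(=O)CC(C)(C)C)c(O)c2C)cccc1C(=O)O` gives 1.77 h, and the two sit level, since the step of a 1.3-fold higher number from compound 2 to compound 3 (0.12 log units; within the scatter) stays within the scatter. Compound 1 `CCCC(=O)c1ccc(OCCCCOc2cc(C(=O)O)ccc2OC)c(C)c1O` gives 0.467 h, a clearly shorter half-life than that of compound 2, with a gap beyond the scatter.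

Compound 4 `CCC(=O)c1ccc(OCCCCOc2ccc(F)c(C(=O)O)c2)c(C)c1O` has not yet been measured. It departs from compound 2 by methyl in place of tert-butyl on a saturated chain carbon bound to a carbonyl carbon, so that neopentylcarbonyl gives way to propanoyl.

Within the data shown here, no measured step covers this change. The only one, a 1.3-fold higher number from compound 2 to compound 3 (0.12 log units; within the scatter), swaps 3-carboxy-4-fluorophenyl for 3-carboxy-2-methylphenyl at a different place and says little here. Among the measured compounds shown here, the one weak hint is compound 1, which also lacks the tert-butyl and gives 0.467 h, although it differs from compound 2 elsewhere as well, so the two effects cannot be separated. A modest fall is therefore expected rather than a large one, and the direction is held with little confidence. The estimated move is a 1.8-fold lower number from compound 2 to compound 4 (0.25 log units; within the scatter). For compound 4 the expected half-life is 0.75 h, with an estimated range from 0.33 h to 1.7 h.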

Compound 4, half-life: 0.367 h
Compound 4: the middle estimate sits 2.0-fold (0.31 log units) above what was measured; low and high end bracket the measured number.
By their numbers in this assay, from the lowest: compounds 4 and 1 (each within the scatter of the next); then compounds 2 and 3 (each within the scatter of the next).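

In this assay, among these compounds, the change from tert-butyl to methyl on a saturated chain carbon bound to a carbonyl carbon gives the first reading at this place with the rest of the molecule held constant. Among the compounds shown here, the result (a 3.6-fold lower number from compound 2 to compound 4 (0.56 log units; beyond the scatter)) lies beyond the scatter and shows that the group at this place matters for the half-life, which the only earlier step (a 1.3-fold higher number from compound 2 to compound 3 (0.12 log units; within the scatter)) could not show, since it concerned a different place and stayed within the scatter. No measurement on hand accounts for the shorter half-life of compound 4.

The compounds shown leave open how the half-life runs between the two ends of this change, since this single step cannot tell whether an isopropyl or a cyclopropyl group at the same place would stay close to tert-butyl, close to methyl or somewhere else. They also leave open whether replacing tert-butyl with methyl would have a similar effect alongside the 3-carboxy-2-methylphenyl group of compound 3 rather than the 3-carboxy-4-fluorophenyl group of compound 2.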